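Chloro-tetrahydropyran series: isobutyl extension from compound 2

The source may report more compounds than this note shows. Statements on the series, on what has been measured and on what is new or still open speak of the compounds shown alone.

Measured so far:
compound 1 `CC(C)C[C@H]1C[C@@H](Cl)CCO1`: > 100000 nM
compound 2 `CC(C)C[C@H]1C[C@@H](Cl)C[C@@H](C)O1`: > 100000 nM

In a functional assay on WiDr cells (Homo sapiens) for antiproliferative activity (on this read-out lower numbers stand for stronger inhibition of growth and higher numbers for weaker inhibition of growth), compound 1 reaches only the assay limit, > 100000 nM. Compound 2 likewise gives only a limit in this assay, > 100000 nM. The step that the two limits leave unreadable from compound 1 to compound 2 therefore cannot be sized, because of the limit of > 100000 nM in this assay, at which 2 of the 2 values shown sit.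

Compound 3 `CC(C)C[C@@H]1C[C@H](Cl)C[C@H](CC(C)C)O1` carries isopropyl in place of hydrogen on a saturated chain carbon bound to a saturated ring carbon. For the measured compounds named here, no readable measured step bears on this change; the single measured step is unreadable. Compound 3 is accordingly expected to remain at the limit, with an estimate of 150000 nM (range 40000 nM to 600000 nM). The expected step that the limit leaves unreadable from compound 2 to compound 3 is thus not expected to reach beyond the scatter.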

Compound 3, concentration for 50% growth inhibition: > 100000 nM
Compound 3 ended at the assay's limit; the forecaster's own chance of this, stated with the estimate: 80%; the middle value is on the limit's open side.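

In this assay, for the compounds shown here, no step among compound 1, compound 2 and compound 3 can be read, as all three give only a limit: the limit of > 100000 nM in this assay, at which 3 of the 3 values shown sit. From the compounds shown here alone, whether any change on the shared core gives a readable value remains open.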